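The compounds below may be only part of what the source reports. "The series", "measured", "known", "first", "only" and "open" are said of these compounds alone.

Measured so far in a functional assay (trachea) with Cavia porcellus as the target; a lower number here means a stronger inhibitor, a higher number a weaker inhibitor:

Compound 1, `CC1(C)C=C(c2cccc[n+]2[O-])c2cc(Br)ccc2C1=O`, gives 230 nM.
Compound 2, `COC1(c2cccc[n+]2[O-])CC(C)(C)C(=O)c2ccc(Br)cc21`, gives only a limit, > 10000 nM.
Compound 3, `CC1(C)C=C(c2cccc[n+]2[O-])c2cc(Cl)c(Cl)cc2C1=O`, gives 210 nM.

Compound 1 has the higher of the two numbers, yet its gap to compound 3 lies within the scatter, so the two cannot be ranked. The value of compound 2 is the limit of > 10000 nM in this assay, at which 1 of the 3 values shown sits, and not a measured number. Compound 4, `CC1(C)C=C(c2cccc[n+]2[O-])c2cc(C(F)(F)C(F)(F)F)ccc2C1=O`, differs from compound 1 in one place: 1,1,2,2,2-pentafluoroethyl in place of bromo on an aromatic carbon. Going by the values given here, no step between measured compounds is known here, so the size of this change has no precedent. In this assay the step of a 1.3-fold lower number from compound 1 to compound 4 (0.11 log units; within the scatter) is expected to be small, at most a modest drop in the number, not far beyond the scatter. Compound 4 is therefore estimated at 180 nM, within a range from 60 nM to 550 nM.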

Compound 4, half-maximal inhibitory concentration: 110 nM
Compound 4: the middle estimate sits 1.6-fold (0.21 log units) above what was measured; measured number inside the range.
By their numbers in this assay, from the lowest: compounds 4, 3 and 1 (each within the scatter of the next, the first and the last beyond it). At a limit, above all of these: compound 2.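

This position on the carbon-only aromatic ring accepts a group with many more heavy atoms than bromo: in this assay, 1,1,2,2,2-pentafluoroethyl in place of bromo brings a 2.1-fold lower number from compound 1 to compound 4 (0.32 log units; beyond the scatter) and so a modest gain rather than a loss. Going by these compounds alone, this is the first single change whose size can be read at this position. Nothing in the data at hand accounts for the gain. Still open, as far as these compounds go, is how an amine, a carboxylic acid or a longer fluorinated chain would fare at this position.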